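Methyl in Place of Fluorophenyl on a Sulfonate

A few compounds are considered here, and "the series" means these few. Any claim that something is new, unique, unknown or untested is made for them only; others in the source may bear on it.

Compound 1 `O=c1cc(-n2cc(COc3ccccc3)nn2)c2cc(Br)ccc2o1`: 1720 nM
Compound 2 `O=c1cc(-n2cc(COc3ccccc3)nn2)c2ccc(OS(=O)(=O)c3ccc(F)cc3)cc2o1`: > 50000 nM

Of the compounds shown here, two sharing a common core have been measured in a functional assay on MCF7 cells (Homo sapiens) for antiproliferative activity, read by MTT assay, with a stated time of 48 h; a lower number here means a stronger inhibitor, a higher number a weaker inhibitor. Compound 1 gives 1720 nM in this assay. For compound 2, this assay reports no number, only a limit, > 50000 nM; this is the limit of > 50000 nM in this assay, at which 1 of the 2 values shown sits. Going by the values given here, since no step between compound 1 and compound 2 is computed, only the two values themselves can be stated: one is a measured number, the other a limit.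

Compound 3 `CS(=O)(=O)Oc1ccc2c(-n3cc(COc4ccccc4)nn3)cc(=O)oc2c1` has not yet been measured. It differs from compound 2 by methyl in place of 4-fluorophenyl on a sulfonyl sulfur. Among the compounds with values here, no measured step in this assay touches this part of the molecule, so the direction and size of the change have no precedent within these data. Because compound 2 already sits at the limit of > 50000 nM in this assay, at which 1 of the 2 values shown sits, the starting point is itself uncertain, and a shift in either direction would be difficult to read.

Compound 3 is therefore expected to come out near 40000 nM, with a plausible range from 8000 nM to 150000 nM. The step this estimate implies, an at least 1.2-fold lower number from compound 2 to compound 3 (0.09 log units; that floor lies within the scatter), is expected to stay within the scatter, with a real chance that this assay again reports only a limit.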

Compound 3, half-maximal inhibitory concentration: 45800 nM
For compound 3 the middle estimate is 1.1-fold (0.06 log units) below the measured one; the range from low to high includes it.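

In this assay, compound 3 gives a measured number for a sulfonate at this part of the molecule, where the earlier data offered none. Compound 2 has no number, only a limit: the limit of > 50000 nM in this assay, at which 1 of the 3 values shown sits. Methyl in place of 4-fluorophenyl on a sulfonyl sulfur gives an at least 1.0-fold lower number from compound 2 to compound 3 (0.03 log units; that floor lies within the scatter), so the data show no change beyond the scatter, yet they cannot fix the true size of the step, since it starts from a limit and could be larger.

The compounds shown leave open whether any other group on the sulfonyl sulfur, such as a longer carbon chain or an amine, would bring a clearly lower number in this assay. Compound 1 also differs from compound 2 and compound 3 in more than one place, so no single change links the value of compound 1 to either sulfonate, and what separates them remains unresolved.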